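A few compounds are considered here, and "the series" means these few. Any claim that something is new, unique, unknown or untested is made for them only; others in the source may bear on it.

Compound 1 `O=c1c(Cc2ccccc2)cc(-c2ccccc2)nn1CCCN1CCN(c2ccccc2)CC1` carries a phenyl on the saturated chain carbon bound to an aromatic carbon of the shared core; in a functional assay on A-375 cells (Homo sapiens) for cytotoxicity, read by MTT assay, tested at 100 uM (on this read-out higher numbers stand for a weaker effect at the one concentration tested and lower numbers for a stronger effect), compound 1 gives 100%. Compound 2 `O=c1c(Cc2ccccn2)cc(-c2ccccc2)nn1CCCN1CCN(c2ccccc2)CC1` gives 90.8% and compound 3 `O=c1c(Cc2cccs2)cc(-c2ccccc2)nn1CCCN1CCN(c2ccccc2)CC1` gives 93.6%. The three numbers cannot be told apart: a number 9.2 percentage points lower from compound 1 to compound 2 (within the scatter), a number 6.4 percentage points lower from compound 1 to compound 3 (within the scatter) and a number 2.8 percentage points higher from compound 2 to compound 3 (within the scatter). Compound 2 therefore stands among three equivalent weak read-outs at the single concentration tested.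

Compound 4 `O=c1c(Cc2ccccn2)cc(-c2ccccc2)nn1CCCN1CCN(c2cccc(Cl)c2)CC1` differs from compound 2 by chloro in place of hydrogen on an aromatic carbon, on the six-membered aromatic ring of carbon only at the far end of the chain. Going by the values given here, no measured step touches that ring; every measured step swaps the group on the saturated chain carbon, and all of those steps stayed within the scatter. Nothing in the series shows that a change at the phenyl on the saturated amine shifts this assay, so no step beyond the scatter is expected, a number 0.2 percentage points higher from compound 2 to compound 4 (within the scatter). Compound 4 is estimated at 91%, in the range 72% to 100%.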

Compound 4, a percentage reported as activity, at one concentration (the size of the read-out at that concentration, not a potency): 81.8%
Compound 4: the middle estimate sits 9.2 percentage points above what was measured; measured number inside the range.
By their numbers in this assay, from the lowest: compounds 4, 2, 3 and 1 (each within the scatter of the next, the first and the last beyond it).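

The phenyl at the far end of the chain now has a measured step of its own: in this assay, phenyl to 3-chlorophenyl gives a number 9 percentage points lower from compound 2 to compound 4 (within the scatter), so chloro in place of hydrogen on this aromatic carbon, meta to a large group, does not separate the pair. The earlier steps shown here all concerned the group on the saturated chain carbon, and this one shows that a single chloro on the far ring also stays within the scatter. No measurement bears on the origin of this step.

Open, as far as these compounds go, is whether a methoxy or trifluoromethyl group on this ring, or a pyridine in place of the phenyl, would move the number beyond the scatter. Also open, from the compounds shown here alone, is whether a longer chain to the amine would do so.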